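The compounds below may be only part of what the source reports. "The series", "measured", "known", "first", "only" and "open" are said of these compounds alone.

Compounds measured: compound 1 `CCC(CC)(CC(=O)Nc1cccc(OCc2ccc3cc(C)c(C)cc3n2)c1)C(=O)O` with 11 nM; compound 2 `CCC(C)(CC(=O)Nc1cccc(OCc2ccc3ccc(F)cc3n2)c1)C(=O)O` with 6.4 nM; compound 3 `CCCC(CCC)(CC(=O)Nc1cccc(OCc2ccc3ccc(F)cc3n2)c1)C(=O)O` with 2 nM.

These three share a core and differ in the acid-bearing chain and in the substituents on the ring system. In a functional assay on ileum (Cavia porcellus) for antagonist activity at cysteinyl leukotriene receptor (Homo sapiens) (on this read-out higher numbers stand for weaker inhibition and lower numbers for stronger inhibition), compound 3 gives the lowest number of the three: compound 2 sits higher, and compound 1 higher still. Among the compounds with values here, the only one-place step among them is a 3.2-fold lower number from compound 2 to compound 3 (0.51 log units; beyond the scatter), which shows that lengthening the branches of the chain went with a stronger inhibition.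

Compound 4 `CCC(CC)(CC(=O)O)C(=O)Nc1cccc(OCc2ccc3ccc(F)cc3n2)c1` carries 1-(carboxymethyl)-1-ethylpropyl in place of 2-carboxy-2-propylpentyl on a carbonyl carbon. This is two changes at once: the acid and the amide exchange their positions along the chain, so that the amide nitrogen now sits on the branched carbon, and the propyl branches shrink to ethyl. Within the data shown here, no measured pair speaks to the exchange of positions. The shrinking of the branches points the other way from the step from compound 2 to compound 3, and compound 1, which carries ethyl branches on a different ring pattern, sits well above compound 3 in this assay.

Compound 4 is therefore expected to give a weaker inhibition than compound 3, a step of about a 7.5-fold higher number from compound 3 to compound 4 (0.88 log units; beyond the scatter), with wide uncertainty. The estimate for compound 4 in this assay is 15 nM, within a range from 3 nM to 80 nM.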

Compound 4, half-maximal inhibitory concentration: 140 nM
The estimate for compound 4 lay 9.3-fold (0.97 log units) below the measured number; measured number above the stated range.
By their numbers in this assay, from the lowest: compound 3; then compounds 2 and 1 (each within the scatter of the next); then compound 4.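

In this assay, placing 1-(carboxymethyl)-1-ethylpropyl on a carbonyl carbon whose other neighbour is an amide-type nitrogen costs much inhibition: replacing 2-carboxy-2-propylpentyl gives a 70-fold higher number from compound 3 to compound 4 (1.85 log units; beyond the scatter), and replacing 2-carboxy-2-methylbutyl gives a 22-fold higher number from compound 2 to compound 4 (1.34 log units; beyond the scatter). Within the data shown here, both steps are large, whichever of the two chains leaves, and both exceed a 3.2-fold lower number from compound 2 to compound 3 (0.51 log units; beyond the scatter), the only change among the earlier compounds that stays within one chain arrangement, so this position tolerates the new chain far less well than those earlier numbers suggested. No measurement given here accounts for this loss of inhibition.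

The shown compounds do not separate the exchange of acid and amide along the chain from the shrinking of the branches, and whether 1-(carboxymethyl)-1-propylbutyl, with its longer branches, would give a lower number than compound 4 stays open. From the compounds shown here alone, it also remains open how a longer chain between the branched carbon and the carboxylic acid would read in this assay.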